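A few compounds are considered here, and "the series" means these few. Any claim that something is new, unique, unknown or untested is made for them only; others in the source may bear on it.

In a physicochemical assay for solubility, read by HPLC, in phosphate buffer, with a stated time of 24 h, at pH 7.4 (a lower number here means a less soluble compound, a higher number a more soluble compound), compound 1 (`COc1ccc(Cn2nnc(O)c2C(=O)Nc2cccc(C(F)(F)F)c2)cc1`) gives 21200 nM and compound 2 (`COc1ccc(Cn2nnc(O)c2C(=O)Nc2cc(C(F)(F)F)cc(C(F)(F)F)c2)cc1`) gives 6910 nM as measured values. Compound 3 (`COc1ccc(Cn2nnc(O)c2C(=O)Nc2cccc(-c3ccccc3)c2)cc1`) gives < 1000 nM as its reading, and this is a limit of the assay, not a number. Among the compounds with values here, two measured steps bear on what follows. Trifluoromethyl in place of hydrogen gave a 3.1-fold lower number from compound 1 to compound 2 (0.49 log units; beyond the scatter) as a modest drop, while phenyl in place of trifluoromethyl gave an at least 21-fold lower number from compound 1 to compound 3 (1.32 log units; beyond the scatter) as a large one. Compound 4 (`COc1ccc(Cn2nnc(O)c2C(=O)Nc2cccc(-c3ccc(O)cc3)c2)cc1`) differs from compound 3 on that phenyl (hydroxy in place of hydrogen on an aromatic carbon) with hydroxy in place of hydrogen on an aromatic carbon, so that phenyl becomes 4-hydroxyphenyl. Neither measured step adds a hydroxy, so they show how far changes on this part of the structure have moved the numbers, but not the direction here. With only a limit for compound 3, a small rise or no step beyond the scatter is expected in this assay for this change. The expected step is a number no lower from compound 3 to compound 4 (the limit leaves the size open) on this reasoning. Compound 4 is estimated at 1000 nM with an expected range from 400 nM to 4000 nM in this measurement.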

Compound 4, solubility: 2050 nM
Compound 4: middle estimate off by 2.1-fold (0.31 log units), on the low side, within the range that was stated.
By their numbers in this assay, from the lowest: compound 4; then compound 2; then compound 1. At a limit, below all of these: compound 3.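

In this assay, hydroxy in place of hydrogen on an aromatic carbon gave an at least 2.0-fold higher number from compound 3 to compound 4 (0.31 log units; beyond the scatter), the only upward step among the compounds shown, so the phenyl is a place where the number can be raised as well as lowered. Compound 3 reads at a limit and not a number, so this step gives only the least that the change can amount to: the limit of < 1000 nM in this assay, at which 1 of the 4 values shown sits. Even so, the 4-hydroxyphenyl compound stays well short of the trifluoromethyl compound, with a 10-fold lower number from compound 1 to compound 4 (1.01 log units; beyond the scatter).

What the compounds shown leave open is whether an amine or a carboxylic acid in the same place on that ring would move the number further than hydroxy does. They also leave open whether a hydroxy gives a similar step on other positions of the ring.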